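From benzyl to 4-chlorobenzyl on the shared core

The source may hold more compounds than are shown below. What is called first, only, known or untested is meant among the compounds shown, and "the series" means these compounds.

In a functional assay on PC-3 cells (Homo sapiens) for antiproliferative activity, read by MTT assay, with a stated time of 48 h (on this read-out lower numbers stand for stronger inhibition and higher numbers for weaker inhibition), compound 1 `COc1ccc(CN(C(=O)CSc2nc3ccccc3s2)c2cc(OC)c(OC)c(OC)c2)cc1[N+](=O)[O-]` gives 26500 nM while compound 3 `COc1cc(N(Cc2ccccc2)C(=O)CSc2nc3ccccc3s2)cc(OC)c1OC` gives 54100 nM as the higher of these two numbers. Compound 2 `COc1cc(CN(C(=O)CSc2nc3ccccc3s2)c2cc(OC)c(OC)c(OC)c2)cc(OC)c1OC` shows > 80000 nM as a limit of the assay and not a number.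

Compound 4 `COc1cc(N(Cc2ccc(Cl)cc2)C(=O)CSc2nc3ccccc3s2)cc(OC)c1OC` differs from compound 3 by chloro in place of hydrogen on an aromatic carbon in the change from benzyl to 4-chlorobenzyl, with chloro para to a large group. Three measured steps altered that same aromatic group: a 2.0-fold higher number from compound 1 to compound 3 (0.31 log units; beyond the scatter) and an at least 3.0-fold higher number from compound 1 to compound 2 (0.47 log units; beyond the scatter) both lie beyond the scatter, while an at least 1.4-fold lower number from compound 2 to compound 3 (0.16 log units; that floor lies within the scatter) has a floor within it. None of them adds chloro, so they guide only the size of the step. Guided by a 2.0-fold higher number from compound 1 to compound 3 (0.31 log units; beyond the scatter) as the one exact step, a small shift toward a lower number is expected, though the heavily substituted compound 2 goes against any simple trend. The expected step is a 1.4-fold lower number from compound 3 to compound 4 (0.13 log units; within the scatter) on this estimate. Compound 4 is therefore expected at 40000 nM in this assay with an estimated range from 15000 nM to 80000 nM as its two ends.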

Compound 4, half-maximal inhibitory concentration: > 80000 nM
Compound 4: only a limit was reported (the forecaster's own chance of this, stated with the estimate: 15%); at least 2.0-fold (0.30 log units) between middle value and limit.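

In this assay, putting chloro on this aromatic carbon gives an at least 1.4-fold higher number from compound 3 to compound 4 (0.16 log units; that floor lies within the scatter), so no gain in inhibition appears, though the floor of this step is too small to settle its size. The 4-methoxy-3-nitrophenyl group now stands out more clearly, since replacing it with 4-chlorophenyl gives an at least 3.0-fold higher number from compound 1 to compound 4 (0.47 log units; beyond the scatter), and compounds 2, 3 and 4 all read higher than compound 1. The step from compound 2 to compound 4 cannot be read, as each carries a limit of the assay and not a number: the limit of > 80000 nM in this assay, at which 2 of the 4 values shown sit.

On these data alone, how far compound 4 really lies past its limit stays open, and so does the true size of the chloro step. Also open, as far as these compounds go, is how an amine or a carboxylic acid on this same aromatic carbon would read in this assay.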